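Aryl amide to pyrrolidine amide in a weakly cytotoxic series

The source may hold more compounds than are shown below. What is called first, only, known or untested is meant among the compounds shown, and "the series" means these compounds.

Of the compounds shown here, two of this set have been tested in an ADME assay on HCT-116 cells (Homo sapiens) for cytotoxicity, read by MTT assay, with a stated time of 72 h; a lower number here means a stronger inhibitor, a higher number a weaker inhibitor. Compound 1 `CCc1cccc(NC(=O)c2cccc(/C=C3\CC(=O)N(Cc4ccccc4)C3=O)c2)c1` is a weak inhibitor, giving 80600 nM in this assay. Compound 2 `Cc1ccc(NC(=O)c2cccc(/C=C3\CC(=O)N(c4ccccc4)C3=O)c2)cc1C` returns only a limit in this assay, namely > 100000 nM. Compound 2 therefore stands at the boundary of what the measurement can report, as recorded by the limit of > 100000 nM in this assay, at which 1 of the 2 values shown sits, and no number for it exists to rank against compound 1. Compound 3 `O=C(c1cccc(/C=C2\CC(=O)N(c3ccccc3)C2=O)c1)N1CCCC1` has not yet been measured; it differs from compound 2 in one place, (pyrrolidin-1-yl in place of (3,4-dimethylphenyl)amino on a carbonyl carbon). Among the measured compounds shown here, no measured pair shows what such a change does, and compound 2 itself offers no value to build on. The step of a number no higher from compound 2 to compound 3 (the limit leaves the size open) is therefore expected to be none beyond the scatter, with compound 3 most likely again reported as a limit. Compound 3 is estimated at 100000 nM, within a range from 30000 nM to 300000 nM.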

Compound 3, half-maximal inhibitory concentration: > 100000 nM
Compound 3 was reported as a limit (the forecaster's own chance of this, stated with the estimate: 60%); the middle value lies on the limit itself.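

Among the compounds shown here, compound 2 and compound 3 are both reported only as limits in this assay, so no step between them can be read: the limit of > 100000 nM in this assay, at which 2 of the 3 values shown sit. The compounds shown leave open what pyrrolidin-1-yl in place of (3,4-dimethylphenyl)amino on a carbonyl carbon does to the value.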